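Urea Aryl Substitution on a Chloropyrazine Benzylamine Scaffold

This account rests on a few compounds, and the source may have more. Where it says the series, first, only, none or still open, it means among the compounds named here.

Measured compounds:
Compound 1 `O=C(Nc1ccccc1)Nc1cccc(CNc2nccnc2Cl)c1` — 19800 nM
Compound 2 `O=C(Nc1cccc(CNc2nccnc2Cl)c1)Nc1ccccc1F` — 7450 nM

Of the compounds shown here, two have been measured in a functional assay on T-24 cells (Homo sapiens) for antiproliferative activity, read by MTT assay, with a stated time of 48 h; a higher number here means a weaker inhibitor, a lower number a stronger inhibitor. Compound 1 `O=C(Nc1ccccc1)Nc1cccc(CNc2nccnc2Cl)c1` gives 19800 nM and sits at the highest of the two numbers; its nearest neighbour is compound 2 `O=C(Nc1cccc(CNc2nccnc2Cl)c1)Nc1ccccc1F`, which gives 7450 nM. Going by the values given here, the one step between them, a 2.7-fold lower number from compound 1 to compound 2 (0.42 log units; beyond the scatter), is modest but beyond the scatter.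

Compound 3 `O=C(Nc1ccc(C(F)(F)F)cc1)Nc1cccc(CNc2nccnc2Cl)c1` has not yet been measured. It differs from compound 1 by trifluoromethyl in place of hydrogen on an aromatic carbon. Among the compounds with values here, the only measured step that bears on this change is the step from compound 1 to compound 2, in which a fluorine entered the same ring and gave a 2.7-fold lower number from compound 1 to compound 2 (0.42 log units; beyond the scatter). Within the data shown here, a trifluoromethyl is a different and larger group, and no measured pair shows directly what it does on this ring, so the direction is inferred only from that one step. On this basis compound 3 is expected to move in the same direction, with a step of about a 2.2-fold lower number from compound 1 to compound 3 (0.34 log units; beyond the scatter). The estimate for compound 3 in this assay is 9000 nM, with a range from 3000 nM to 30000 nM.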

Compound 3, half-maximal inhibitory concentration: 4580 nM
Compound 3: middle estimate off by 2.0-fold (0.29 log units), on the high side; low and high end bracket the measured number.
By their numbers in this assay, from the lowest: compounds 3 and 2 (each within the scatter of the next); then compound 1.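

In this assay, trifluoromethyl on an aromatic carbon, para to a large group, gives a 4.3-fold lower number from compound 1 to compound 3 (0.64 log units; beyond the scatter). This shows that the ring of compound 1 accepts a group of 4 heavy atoms at this place, and that the number falls rather than rises with it. Compound 1, which carries only hydrogen on that ring, now has the highest number of the three compounds, so both substituted compounds lie on the same side of it, and none of the three goes against this; nothing available measures why trifluoromethyl has this effect here.

The compounds shown leave open whether this trend is specific to trifluoromethyl or extends to other groups at the same place, such as a methoxy group, an amine or a carboxylic acid. They also leave open what trifluoromethyl would do on another carbon of the same ring, and whether a second group on that ring would lower the number further.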